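Working notes on tolerability of compound 2 and compound 3

The source may hold more compounds than are shown below. What is called first, only, known or untested is meant among the compounds shown, and "the series" means these compounds.

Compound 1 `CCOC(=O)c1cn(COCCO)c(=S)[nH]c1=O` and compound 2 `Cc1cc(=O)[nH]c(=O)n1COCCO` have both been tested in a functional assay on HepG2 cells (Homo sapiens) for cytotoxicity, read by MTT assay; a lower number here means that less compound is tolerated, a higher number that more compound is tolerated. For compound 1 this assay gives only a limit, > 364000 nM. For compound 2 this assay likewise gives only a limit, > 500000 nM. Among the compounds with values here, compound 2 therefore stands at a limit rather than at a number, and the one further value available for compound 1 is a limit as well (the limit of > 364000 nM in this assay, at which 1 of the 2 values shown sits, (the limit of > 500000 nM in this assay, at which 1 of the 2 values shown sits)); no step between measured compounds can be read from this pair, so no size of change is known.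

Compound 3 `COC(=O)c1cc(=O)[nH]c(=O)n1COCCO` is not yet measured. It differs from compound 2 by methoxycarbonyl in place of methyl on an aromatic carbon. Nothing measured here tells how this change bears on this assay. The expected step from compound 2 to compound 3 in this assay is none beyond the scatter, estimated as an at least 1.2-fold lower number from compound 2 to compound 3 (0.09 log units; that floor lies within the scatter). Compound 3 is accordingly estimated at 400000 nM in this assay, within 150000 nM to 1000000 nM, with a strong chance that this assay again reports only a limit.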

Compound 3, half-maximal cytotoxic concentration: > 409000 nM
Compound 3 gave a limit, no number; the forecaster's own chance of this, stated with the estimate: 75%; at least 1.0-fold (0.00 log units) between middle value and limit.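

Within the data shown here, compound 2 and compound 3 both stand only at limits in this assay, and no step between them can be read. The compounds shown leave open at what concentration, if any, compound 1, compound 2 or compound 3 reaches half-maximal cytotoxicity, and whether methoxycarbonyl in place of methyl on an aromatic carbon alters it.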